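Methyl to Methoxy on the Lowest of Three Compounds

The compounds below may be only part of what the source reports. "The series", "measured", "known", "first", "only" and "open" are said of these compounds alone.

Compound 1 `Cc1ccc(S(=O)(=O)Oc2ccccc2/C=C(\C#N)C(=O)Nc2nnc(C)s2)cc1` gives 78%
Compound 2 `COc1ccc(S(=O)(=O)Oc2ccccc2/C=C(\C#N)C(=O)Nc2nnc(-c3cccs3)s2)cc1` gives 67%
Compound 3 `COc1ccc(Cc2nnc(NC(=O)/C(C#N)=C/c3ccccc3OS(=O)(=O)c3ccc(C)cc3)s2)cc1` gives 25%

In a functional assay on HL-60 cells (Homo sapiens) for inhibition, read by CCK-8 assay, with a stated time of 48 h, tested at 20 uM (on this read-out higher numbers stand for more inhibition of growth at the one concentration tested and lower numbers for less inhibition of growth), compound 3 stands lowest of the three, well under both others. Compound 4 `COc1ccc(Cc2nnc(NC(=O)/C(C#N)=C/c3ccccc3OS(=O)(=O)c3ccc(OC)cc3)s2)cc1` differs from it by methoxy in place of methyl on an aromatic carbon. Among the compounds with values here, the only measured step is a number 53 percentage points lower from compound 1 to compound 3 (beyond the scatter) and it lies at a different place, so it sets no size for this swap. Compound 2 carries the same (4-methoxyphenyl)sulfonyl group and reads 67% but differs from compound 3 elsewhere too, so it isolates nothing. The expected result is a number 3 percentage points higher from compound 3 to compound 4 (within the scatter) and no shift beyond the scatter is expected. Compound 4 is estimated at 28% on this read-out, with an expected range from 12% to 48% in repeat measurements.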

Compound 4, percent growth inhibition at one concentration: 100%
Compound 4: the middle estimate sits 72 percentage points below what was measured; the whole stated range lies below it.
By their numbers in this assay, from the lowest: compound 3; then compound 2; then compound 1; then compound 4.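

In this assay, the position para to a large group on the sulfonyl-bearing aromatic ring proves highly sensitive, since methoxy in place of methyl gives a number 75 percentage points higher from compound 3 to compound 4 (beyond the scatter). With the (4-methoxyphenyl)sulfonyl group held constant, 4-methoxybenzyl in place of thiophen-2-yl gives a number 33 percentage points higher from compound 2 to compound 4 (beyond the scatter), so this group need not lower the number when methoxy is present. Nothing available explains why the swap has this effect.

On these data alone, whether an amine or an ethoxy group at this position would hold the number stays open. So does whether methoxy in place of methyl would act alike on compound 1 .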